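The source may hold more compounds than are shown below. What is called first, only, known or untested is meant among the compounds shown, and "the series" means these compounds.

Measured so far:
- compound 1, `Cc1n[nH]c2ccc(-c3nc4cnc(N5CCN(C)CC5)cn4c3Nc3cccc(F)c3)cc12`: 5.41%
- compound 2, `Cc1n[nH]c2ccc(-c3nc4cnc(N5CCN(C)CC5)cn4c3Nc3ccccc3)cc12`: "not determined" (no result reported)

Compound 1 carries a fluorine-bearing phenyl on the ring nitrogen and, in a functional assay on CWR22R cells (Homo sapiens) for inhibition, with a stated time of 120 h, tested at 10 uM (a higher number here means more inhibition at the concentration tested (going by the name of the read-out), a lower number less inhibition), compound 1 gives 5.41%, a small number for this read-out. Compound 2, `Cc1n[nH]c2ccc(-c3nc4cnc(N5CCN(C)CC5)cn4c3Nc3ccccc3)cc12`, has a plain phenyl in that position; in this assay compound 2 gives "not determined" (no result reported), so no single number is available for it. Compound 3, `COc1ccc(Nc2c(-c3ccc4[nH]nc(C)c4c3)nc3cnc(N4CCN(C)CC4)cn23)cc1OC`, differs from compound 2 in one place: 3,4-dimethoxyphenyl in place of phenyl on a nitrogen on an aromatic ring.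

Among the measured compounds shown here, no step between measured compounds is known for this pair, and compound 2 has no number of its own. With compound 1 giving 5.41% as the only anchor, a step in this assay is expected to stay within the usual scatter, with no clear direction either way. Compound 3 is therefore estimated to give 10% in this assay, with a range of 0% to 35%.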

Compound 3, a percentage reported as inhibition, at one concentration (the size of the read-out at that concentration, not a potency): 0%
The estimate for compound 3 lay 10 percentage points above the measured number; measured number inside the range.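

In this assay the change from 3-fluorophenyl to 3,4-dimethoxyphenyl on a nitrogen on an aromatic ring gives a number 5.4 percentage points lower from compound 1 to compound 3 (within the scatter), so the two compounds cannot be told apart in this read-out. Among the compounds shown here, this is the first comparison at this position that can be read, and it shows that this place accepts a larger group, with 10 heavy atoms and 2 hydrogen-bond acceptors, without the read-out leaving the small numbers seen so far. Nothing measured here offers an explanation for this result.

Compound 2 has no number and the steps from its plain phenyl cannot be read, which leaves open whether either substituted ring differs from the unsubstituted one. Also open, as far as these compounds go, is whether a ring carrying an amine or a carboxylic acid, or a longer alkyl chain in place of the ring on that nitrogen, would give a clearly higher number in this assay than these two compounds do.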